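Iodo in Place of Hydrogen on a Ring Carbon

The compounds below may be only part of what the source reports. "The series", "measured", "known", "first", "only" and "open" are said of these compounds alone.

The compounds were compared in a functional assay on SUP-B15 cells (Homo sapiens) for antiproliferative activity, with a stated time of 72 h; on this read-out higher numbers stand for an effect only at larger amounts of compound and lower numbers for an effect already at smaller amounts. Compound 1 `COc1ccc(-c2cc(=O)c3c(OC)cc(OC)cc3[nH]2)cc1` bears a hydrogen on its aromatic nitrogen. In this assay compound 1 gives > 62000 nM, which is a limit of the assay and not a number. Compound 2 `COc1ccc(-c2cc(=O)c3c(OC)cc(OC)cc3n2Cc2ccccc2)cc1` carries a benzyl on that nitrogen, and in this assay compound 2 also stops at a limit, > 34400 nM. Within the data shown here, compound 3 `C=CCNC(=O)n1c(-c2ccc(OC)cc2)cc(=O)c2c(OC)cc(OC)cc21` carries an allylcarbamoyl on the nitrogen, and in this assay compound 3 is the only one to give a number, 16000 nM. The step that the two limits leave unreadable from compound 1 to compound 2 cannot be read owing to the limit of > 34400 nM in this assay, at which 1 of the 3 values shown sits, and (the limit of > 62000 nM in this assay, at which 1 of the 3 values shown sits). The readable steps are an at least 3.8-fold lower number from compound 1 to compound 3 (0.58 log units; beyond the scatter) and an at least 2.1-fold lower number from compound 2 to compound 3 (0.33 log units; beyond the scatter), and both concern the aromatic nitrogen alone.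

Compound 4 `COc1ccc(-c2[nH]c3cc(OC)cc(OC)c3c(=O)c2I)cc1` differs from compound 1 by iodo in place of hydrogen on an aromatic carbon. Among the measured compounds shown here, no measured step touches a ring carbon, so none of them bears directly on this change, and compound 1 itself stands at a limit. The expectation for compound 4 is therefore a step of an at least 1.3-fold lower number from compound 1 to compound 4 (0.13 log units; that floor lies within the scatter), close to no change beyond the scatter, with a likely result near the limit again. The estimate for compound 4 is 45000 nM, between 8000 nM and 150000 nM.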

Compound 4, half-maximal effective concentration: > 86200 nM
Compound 4 gave a limit, no number; the forecaster's own chance of this, stated with the estimate: 60%; at least 1.9-fold (0.28 log units) between middle value and limit.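

In this assay compound 4 gives > 86200 nM, which is a limit of the assay and not a number. Among these compounds, compound 1 also stands at a limit, so no step from compound 1 to compound 4 can be read. The compounds shown leave open whether iodo in place of hydrogen on an aromatic carbon changes the result in this assay at all, in either direction.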